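Carbamoyl in place of methoxy in the cyano-bearing series

A few compounds are considered here, and "the series" means these few. Any claim that something is new, unique, unknown or untested is made for them only; others in the source may bear on it.

In a functional assay on P388 cells (Mus musculus) for antiproliferative activity (on this read-out higher numbers stand for weaker inhibition and lower numbers for stronger inhibition), compound 3 (`COc1ccc(S(=O)(=O)Nc2cccc3c(C#N)c[nH]c23)cc1`) gives the lowest number of the three measured compounds (0.17 ug/mL). Compound 1 (`COc1ccc(S(=O)(=O)Nc2cccc3cc[nH]c23)cc1`) stands higher (1.1 ug/mL), and compound 2 (`Cc1ccc(S(=O)(=O)Nc2cccc3cc[nH]c23)cc1`) higher still (4.3 ug/mL). Compound 4 (`N#Cc1c[nH]c2c(NS(=O)(=O)c3ccc(C(N)=O)cc3)cccc12`) has not yet been measured in this assay. It differs from compound 3 by carbamoyl in place of methoxy on an aromatic carbon, para to a large group (carbamoyl in place of methoxy on an aromatic carbon).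

For the measured compounds named here, two measured steps bear on this change. The closer one also removes methoxy (a 3.9-fold higher number from compound 1 to compound 2 (0.59 log units; beyond the scatter)). It puts methyl in its place, and this modest step, beyond the scatter, goes toward weaker inhibition. Methyl is not carbamoyl, however, and no measured compound carries carbamoyl, so this guide is only partial. The second step adds cyano in place of hydrogen (a 6.5-fold lower number from compound 1 to compound 3 (0.81 log units; beyond the scatter)). It is also modest and beyond the scatter, and compound 4 keeps that cyano. A modest move toward weaker inhibition is therefore expected, of about the size seen on leaving methoxy for methyl, with the direction far from certain. The expected step is a 2.9-fold higher number from compound 3 to compound 4 (0.47 log units; beyond the scatter) (an estimate). For compound 4 the estimated value is 0.5 ug/mL (expected range 0.12 ug/mL to 2 ug/mL).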

Compound 4, half-maximal inhibitory concentration: 2.5 ug/mL
For compound 4 the middle estimate is 5.0-fold (0.70 log units) below the measured one; the measured number lies above the stated range.
By their numbers in this assay, from the lowest: compound 3; then compound 1; then compounds 4 and 2 (each within the scatter of the next).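

In this assay, carbamoyl in place of methoxy on this aromatic carbon, para to a large group, gives a 15-fold higher number from compound 3 to compound 4 (1.17 log units; beyond the scatter), a large step toward weaker inhibition. The earlier compounds showed a modest loss on leaving methoxy only without the cyano group, as a 3.9-fold higher number from compound 1 to compound 2 (0.59 log units; beyond the scatter), so this result extends the loss to the cyano-bearing series: both replacements of methoxy shown raise the number, and no compound shown goes against this. Keeping the cyano group, which accompanies a 6.5-fold lower number from compound 1 to compound 3 (0.81 log units; beyond the scatter), therefore does not keep the number low once methoxy gives way to carbamoyl, and nothing available explains the size of this step.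

The compounds shown leave open whether any group at this place gives a lower number than methoxy, for example an ethoxy group, a fluorine atom or an amine, and whether a carboxylic acid or a methyl ester would follow carbamoyl upward. They also leave open how carbamoyl behaves on the core of compound 1 without the cyano group, and whether the hydrogens on its nitrogen matter, which an N,N-dimethylcarbamoyl group could test.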